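The source may report more compounds than this note shows. Statements on the series, on what has been measured and on what is new or still open speak of the compounds shown alone.

Working notes on the series. Compound 1 `CCOC(=O)c1ccc(NCc2cncn2Cc2ccc(-c3ccccc3)cc2)cc1-c1ccccc1` was tested in a toxicity assay on NIH3T3 cells (Mus musculus) for cytotoxicity, read by resazurin assay; on this read-out higher numbers stand for an effect only at larger amounts of compound and lower numbers for an effect already at smaller amounts; in this assay compound 1 reaches only a limit, > 10000 nM. Compound 2 `Nc1cc(-c2ccccc2)ccc1Cn1cncc1CNc1ccc(-c2nc3ccccc3s2)c(-c2ccccc2)c1` likewise shows only a limit in this assay, > 1000 nM. Compound 3 `Cc1ccccc1-c1cc(NCc2cncn2Cc2ccc(-c3ccccc3)cc2)ccc1-c1nc2ccccc2s1` also stops at a limit in this assay, > 1000 nM. Compound 1 therefore stands at the limit of > 10000 nM in this assay, at which 1 of the 3 values shown sits, whereas compounds 2 and 3 sit at the limit of > 1000 nM in this assay, at which 2 of the 3 values shown sit. Among the compounds with values here, no step between two measured compounds can be drawn from these numbers, as all three are limits. Compound 4 `COc1ccc(NCc2cncn2Cc2ccc(-c3ccccc3)cc2)cc1-c1ccccc1` differs from compound 1 by methoxy in place of ethoxycarbonyl on an aromatic carbon. In this assay no movement beyond the scatter is expected from that exchange. The expected step is a step that the limit leaves unreadable from compound 1 to compound 4. Compound 4 is estimated at 15000 nM, with a range from 5000 nM to 50000 nM.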

Compound 4, half-maximal effective concentration: > 1000 nM
Compound 4: only a limit was reported; the forecaster's own chance of this, stated with the estimate: 70%; the middle value does not contradict the limit.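

Within the data shown here, compound 1 and compound 4 each give only a limit in this assay, and no step between them can be read. The compounds shown leave open at what concentration any of them would produce an effect in this assay.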